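Second fluoro on the aryl of compound 3

A few compounds are considered here, and "the series" means these few. Any claim that something is new, unique, unknown or untested is made for them only; others in the source may bear on it.

Three compounds of the series have numbers in a functional assay for agonist activity at G protein-coupled receptor 88 (Homo sapiens), read by HTRF and cAMP accumulation; on this read-out higher numbers stand for an effect only at larger amounts of compound and lower numbers for an effect already at smaller amounts. Compound 1 `CC(C)C[C@H](N)CN(C(=O)C(C)Cc1ccccc1)c1ccc(-c2ccccc2)cc1` gives 1.2 nM, and compound 2 `N[C@H](CN(C(=O)[C@@H]1C[C@H]1c1ccccc1)c1ccc(-c2ccccc2)cc1)C1CCCCC1` gives 0.66 nM. Compound 3 `CC[C@H](C)[C@H](N)CN(C(=O)[C@@H]1C[C@H]1c1ccc(F)cc1)c1ccc(-c2ccccc2)cc1`, which carries a 2-(4-fluorophenyl)cyclopropyl group on the amide, gives 600 nM, the highest number of the three; the gaps to compound 1 and to compound 2 are both well beyond the scatter, so compound 3 is the least potent of the measured set.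

Compound 4 `CC[C@H](C)[C@H](N)CN(C(=O)[C@@H]1C[C@H]1c1ccc(F)cc1F)c1ccc(-c2ccccc2)cc1` is not yet measured. It differs from compound 3 in one place: fluoro in place of hydrogen on an aromatic carbon, so that 4-fluorophenyl becomes 2,4-difluorophenyl, the new fluoro sitting ortho to a large group and meta to the fluoro already present. Among the measured compounds shown here, no measured pair shows this change, so there is no step to rest on. The expectation for the step from compound 3 to compound 4 is a 1.2-fold lower number from compound 3 to compound 4 (0.08 log units; within the scatter), that is, a small shift in this assay, not clearly beyond the scatter in either direction. Compound 4 is accordingly estimated at 500 nM, with a range of 150 nM to 2000 nM.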

Compound 4, half-maximal effective concentration: 1300 nM
The estimate for compound 4 lay 2.6-fold (0.41 log units) below the measured number; measured number inside the range.
By their numbers in this assay, from the lowest: compounds 2 and 1 (each within the scatter of the next); then compound 3; then compound 4.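

In this assay the series gains its first one-place step: fluoro in place of hydrogen on an aromatic carbon, ortho to a large group and meta to a fluoro group, gives a 2.2-fold higher number from compound 3 to compound 4 (0.34 log units; beyond the scatter). At this position, then, 2-(2,4-difluorophenyl)cyclopropyl is less potent than 2-(4-fluorophenyl)cyclopropyl, by a modest step that rests on this single pair. No accompanying measurement bears on what lies behind the step.

Still open, from the compounds shown here alone, is whether a chloro or a methoxy group in the same place would shift the number as fluoro does, or whether the shift is particular to fluoro. Also open, going by these compounds, is whether the same change on the unsubstituted phenyl of compound 2, with its cyclohexyl group, would move the number in the same direction.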